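Replacing the triazole with an isopropyl amide

The compounds below may be only part of what the source reports. "The series", "measured", "known", "first", "only" and "open" are said of these compounds alone.

Measured so far:
compound 1 `CC(C)C(Cc1nnc[nH]1)c1ccc(-c2ccc3cccc(F)c3c2)[nH]c1=O` — 0.1 h
compound 2 `CC(C)C(c1ncc[nH]1)c1ccc(-c2ccc3cccc(F)c3c2)[nH]c1=O` — < 0.0667 h, a limit of the assay
compound 3 `CC(C)C(CC(N)=O)c1ccc(-c2ccc3cccc(F)c3c2)[nH]c1=O` — < 0.0667 h, a limit of the assay

In an ADME assay on microsomes from liver (Rattus norvegicus) for metabolic stability (on this read-out lower numbers stand for a shorter-lived compound and higher numbers for a longer-lived compound), compound 1 stands as the only number shown. The value of compound 2 is a limit of the assay. The value of compound 3 is likewise a limit. Compound 4 `CC(C)NC(=O)CC(c1ccc(-c2ccc3cccc(F)c3c2)[nH]c1=O)C(C)C` differs from compound 1 by isopropylcarbamoyl in place of 4H-1,2,4-triazol-3-yl on a saturated chain carbon, two bonds along the chain from an aromatic carbon. The closest measured step is an at least 1.4-fold lower number from compound 1 to compound 3 (0.17 log units; that floor lies within the scatter), where carbamoyl took the same place and the number fell to the limit (the limit of < 0.0667 h in this assay, at which 2 of the 3 values shown sit). The step of an at least 1.4-fold lower number from compound 1 to compound 2 (0.17 log units; that floor lies within the scatter) also ends at that limit. A step downward of at least that size is therefore expected for compound 4, quite possibly again to a limit. Compound 4 is estimated at 0.07 h, with a range from 0.03 h to 0.2 h. This corresponds to an expected step of a 1.4-fold lower number from compound 1 to compound 4 (0.15 log units; within the scatter).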

Compound 4, half-life: < 0.0667 h
Compound 4 gave a limit, no number (the forecaster's own chance of this, stated with the estimate: 50%); at least 1.0-fold (0.02 log units) between middle value and limit.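

In this assay, isopropylcarbamoyl in place of 4H-1,2,4-triazol-3-yl gives an at least 1.4-fold lower number from compound 1 to compound 4 (0.17 log units; that floor lies within the scatter). Adding isopropyl to the amide nitrogen of compound 3 therefore yields no readable number, and the steps among compound 2, compound 3 and compound 4 cannot be read. Compound 1 remains the only one with a number, while the others share one limit: the limit of < 0.0667 h in this assay, at which 3 of the 4 values shown sit.

From the compounds shown here alone, how far the three limited compounds lie under that limit stays open. So does whether a carboxylic acid or a tetrazole at this place would give a readable number in this assay.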